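The source may hold more compounds than are shown below. What is called first, only, known or untested is meant among the compounds shown, and "the series" means these compounds.

Of the compounds shown here, three of a shared core have been tested in a functional assay on SW-620 cells (Homo sapiens) for antiproliferative activity, read by MTT assay, with a stated time of 72 h; on this read-out higher numbers stand for weaker inhibition and lower numbers for stronger inhibition. Compound 1 `CC(C)(C)c1cn(C[C@H](O)[C@H]2OC(=O)C(OCc3ccccc3)=C2OCc2ccccc2)nn1` carries a tert-butyl group and gives 35800 nM. Compound 2 `O=C1O[C@H]([C@@H](O)Cn2cc(CNS(=O)(=O)c3ccc(Cl)cc3)nn2)C(OCc2ccccc2)=C1OCc1ccccc1` carries a (((4-chlorophenyl)sulfonyl)amino)methyl group instead and gives 18000 nM; the change gives a 2.0-fold lower number from compound 1 to compound 2 (0.30 log units; within the scatter). Compound 3 `O=C1O[C@H]([C@@H](O)Cn2cc(-c3cc(F)cc(F)c3)nn2)C(OCc2ccccc2)=C1OCc1ccccc1` carries a 3,5-difluorophenyl group in that place. For compound 3 the value > 100000 nM is a limit of the assay, not a number (the limit of > 100000 nM in this assay, at which 1 of the 3 values shown sits). From that limit the two steps read an at least 2.7-fold higher number from compound 1 to compound 3 (0.44 log units; beyond the scatter) and an at least 5.5-fold higher number from compound 2 to compound 3 (0.74 log units; beyond the scatter). Compound 2 thus sits among two numbers and one limit, with compound 1 within the scatter of it.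

Compound 4 `O=C1O[C@H]([C@@H](O)Cn2cc(CNS(=O)(=O)c3ccc(Cl)cc3F)nn2)C(OCc2ccccc2)=C1OCc1ccccc1` differs from compound 2 by a single change: fluoro in place of hydrogen on an aromatic carbon. Within the data shown here, none of the measured steps alters a hydrogen for fluoro on that ring, so no step speaks to this change directly. The step from compound 1 to compound 2, which changes a far larger group, stayed within the scatter, and the addition of one fluorine is a smaller change still. For compound 4 no step beyond the scatter is expected, so the estimate is no change at the digits printed from compound 2 to compound 4 (within the scatter). Compound 4 is therefore estimated at 18000 nM, with a range from 8000 nM to 40000 nM.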

Compound 4, half-maximal inhibitory concentration: 42400 nM
Compound 4: the middle estimate sits 2.4-fold (0.37 log units) below what was measured; the measured number lies above the stated range.
By their numbers in this assay, from the lowest: compounds 2, 1 and 4 (each within the scatter of the next, the first and the last beyond it). At a limit, above all of these: compound 3.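

In this assay, one fluoro in place of hydrogen, on the aromatic carbon ortho to a large group and meta to a chloro group, gives a 2.4-fold higher number from compound 2 to compound 4 (0.37 log units; beyond the scatter). This is the first step shown inside the 4-chlorophenyl part rather than a swap of the whole group, and it shows that this ring is not silent: a change of a single heavy atom here moves the number modestly beyond the scatter, whereas the far larger exchange of tert-butyl for the whole sulfonylaminomethyl group stayed within it. Nothing measured among these compounds accounts for the size or direction of this step.

Going by these compounds, with only one substituent tested at this carbon, it remains open whether the step belongs to fluoro in particular or to any group placed there, as a chloro, a methyl or a methoxy group would show. Also open, on these data alone, is how the number responds to fluoro on the other carbons of this ring, or to an amine or a carboxylic acid in place of the chloro group.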